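A few compounds are considered here, and "the series" means these few. Any claim that something is new, unique, unknown or untested is made for them only; others in the source may bear on it.

Working notes on the series. All three measured compounds share one core and differ only in the group on the carbonyl carbon of the side chain. In a functional assay on the whole organism for inhibition, with Cavia porcellus as the target (a lower number here means that less compound is needed, a higher number that more compound is needed for the effect), compound 1 `CCOC(=O)CC(=O)N1CCSC1COc1ccccc1OC` gives 21 mg/kg. Compound 2 `COc1ccccc1OCC1SCCN1C(=O)CC(=O)O` gives 20 mg/kg in this assay, and the step of a 1.1-fold lower number from compound 1 to compound 2 (0.02 log units; within the scatter) leaves the two indistinguishable. Compound 3 `CCN(CC)CCNC(=O)CC(=O)N1CCSC1COc1ccccc1OC` gives 56 mg/kg in this assay, the highest of the three numbers; the steps of a 2.7-fold higher number from compound 1 to compound 3 (0.43 log units; beyond the scatter) and a 2.8-fold higher number from compound 2 to compound 3 (0.45 log units; beyond the scatter) both lie beyond the scatter, so compound 3 stands apart from the other two.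

Compound 4 `COc1ccccc1OCC1SCCN1C(=O)CC(=O)NCc1cccnc1` has not been measured in this assay. The change from compound 3 is pyridin-3-yl in place of (diethylamino)methyl on a saturated chain carbon bound to an amide-type nitrogen. Among the compounds with values here, no measured step bears directly on this change: the two steps that reach compound 3 each exchange the group on the carbonyl carbon, whereas here the amide-type nitrogen and the saturated chain carbon are kept and only the group on that carbon changes. With nothing in the measured set to point either way, compound 4 is expected to stay near compound 3, a step of a 1.2-fold lower number from compound 3 to compound 4 (0.09 log units; within the scatter) that need not exceed the scatter. The estimate for compound 4 in this assay is 45 mg/kg, with a range from 20 mg/kg to 110 mg/kg.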

Compound 4, dose for half-maximal effect: 57 mg/kg
For compound 4 the middle estimate is 1.3-fold (0.10 log units) below the measured one; the measured number falls inside the stated range.
By their numbers in this assay, from the lowest: compounds 2 and 1 (each within the scatter of the next); then compounds 3 and 4 (each within the scatter of the next).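

At the saturated chain carbon bound to an amide-type nitrogen, this assay does not separate the open (diethylamino)methyl group from the aromatic pyridin-3-yl ring: a 1.0-fold higher number from compound 3 to compound 4 (0.01 log units; within the scatter) is the reading, so this exchange of chain for ring has no visible effect on the number. The second amide-type side chain also stands apart from the ester and the acid, with a 2.7-fold higher number from compound 1 to compound 4 (0.43 log units; beyond the scatter) and a 2.9-fold higher number from compound 2 to compound 4 (0.45 log units; beyond the scatter) as its steps, so among these four compounds the higher numbers go with both amide-type groups on the carbonyl carbon, and none of the four goes against this. No measurement in hand offers an explanation for either observation.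

The compounds shown leave open whether a phenyl ring in place of pyridin-3-yl, or a longer chain carrying the pyridin-3-yl ring on the amide-type nitrogen, would move the number beyond the scatter. They also leave open whether a simple unsubstituted amide on the carbonyl carbon would read with compound 3 and compound 4 or with compound 1 and compound 2.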